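A benzyloxycarbonyl group in place of a guanidine side chain

This account rests on a few compounds, and the source may have more. Where it says the series, first, only, none or still open, it means among the compounds named here.

Compound 1 `N=C(N)NCCC[C@H](NC(=O)CN(c1ncnc2c1ncn2C1CCCCO1)C1CC1)C(=O)OCc1ccccc1` was tested in a functional assay on the whole organism (Tail, strain ICR) with Mus musculus as the target, in the tail flick test, with a stated time of 150 min, at a dose of 25 umol/kg by the oral route (on this read-out lower numbers stand for a weaker effect and higher numbers for a stronger effect at the one dose given), where compound 1 gives 19.6%. Two related compounds show the spread of numbers around it. Within the data shown here, compound 2 `O=C(O)CC[C@H](NC(=O)CN(c1nc(Cl)nc2[nH]cnc12)C1CC1)C(=O)O` gives 29.5% in this assay, a value that lies within the usual scatter of the one seen for compound 1. Compound 3 `NC(=O)CC[C@H](NC(=O)CN(c1nc(Cl)nc2[nH]cnc12)C1CC1)C(=O)OCc1ccccc1` gives 31.1% in this assay, a number that lies beyond the scatter above that of compound 1, so compound 1 stands below compound 3 and alongside compound 2 among the three measured compounds.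

Compound 4 `O=C(CN(c1ncnc2c1ncn2C1CCCCO1)C1CC1)N[C@@H](CC(=O)OCc1ccccc1)C(=O)OCc1ccccc1` has not yet been measured. It differs from compound 1 in one place: a group of 10 heavy atoms (8 carbon, 2 oxygen; one six-membered aromatic ring of carbon only) in place of a group of 6 heavy atoms (3 carbon, 3 nitrogen; no ring), on a saturated chain carbon, two bonds along the chain from an amide-type nitrogen and a carbonyl carbon. Among the measured compounds shown here, no pair of measured compounds that differ in a single place is available, so there is no measured step on which to rest a firm prediction. The change leaves the core of compound 1 and the benzyl ester untouched. All three measured values sit in a narrow band, and the step of a number 4.4 percentage points higher from compound 1 to compound 4 (within the scatter) is therefore expected to stay within the scatter, in no clear direction. Compound 4 is estimated at 24% in this assay, with a range from 10% to 40%.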

Compound 4, a percentage reported as activity, at one dose (the size of the read-out at that dose, not a potency): 0.06%
Compound 4: the middle estimate sits 23.9 percentage points above what was measured; measured number outside the range, below it.
By their numbers in this assay, from the lowest: compound 4; then compounds 1, 2 and 3 (each within the scatter of the next, the first and the last beyond it).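

With the shared core and the benzyl ester held constant, benzyloxycarbonyl in place of the group of 6 heavy atoms (3 carbon, 3 nitrogen; no ring), on a saturated chain carbon, two bonds along the chain from an amide-type nitrogen and a carbonyl carbon, gives a number 19.5 percentage points lower from compound 1 to compound 4 (beyond the scatter) in this assay. Among these compounds, this is the only step in the set that involves a single place, and it shows that a change at this position alone can move the read-out at this one dose beyond the scatter, something the earlier compounds, which differ from one another in more than one place, could not show. Nothing measured here bears on why the number falls with this change.

From the compounds shown here alone, with only one replacement at this place, it remains open whether the fall goes with the arrival of the benzyloxycarbonyl group or with the departure of the group it replaces. A primary amine, a free carboxylic acid or a plain longer carbon chain at the same place on the same core would help to separate these two readings.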